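Swapping halogens on the phenyl ring of a thrombopoietin receptor agonist

This account rests on a few compounds, and the source may have more. Where it says the series, first, only, none or still open, it means among the compounds named here.

Compound 2 `O=C(Nc1nc(-c2ccc(F)c(Br)c2)c(F)s1)c1cnc(N2CCC(C(=O)O)CC2)c(Cl)c1` gives 670 nM in a functional assay on BaF3 cells for agonist activity at thrombopoietin receptor (Homo sapiens) (a higher number here means that more compound is needed for the effect, a lower number that less compound is needed), the highest of the two numbers measured, with compound 1 `O=C(Nc1nc(-c2ccc(F)c(Cl)c2)c(F)s1)c1cnc(N2CCC(C(=O)O)CC2)c(Cl)c1` nearest at 480 nM. Among the compounds with values here, the only measured step, a 1.4-fold higher number from compound 1 to compound 2 (0.14 log units; within the scatter), changes a single halogen on that phenyl ring and stays within the scatter. Compound 3 `O=C(Nc1nc(-c2ccc(Cl)c(Cl)c2)c(F)s1)c1cnc(N2CCC(C(=O)O)CC2)c(Cl)c1` carries 3,4-dichlorophenyl in place of 3-bromo-4-fluorophenyl on an aromatic carbon. Within the data shown here, with both halogens changed, the one step measured suggests little movement, so in this assay compound 3 is expected at 500 nM, between 200 nM and 1500 nM, a step of a 1.3-fold lower number from compound 2 to compound 3 (0.13 log units; within the scatter) that is not expected to exceed the scatter.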

Compound 3, half-maximal effective concentration: > 1000 nM
Compound 3 ended at the assay's limit; the forecaster's own chance of this, stated with the estimate: 5%; at least 2.0-fold (0.30 log units) between middle value and limit.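

Unlike the bromo-for-chloro swap, putting chloro in place of the fluoro on the phenyl ring does move the result beyond the scatter: the step, an at least 2.0-fold higher number from compound 1 to compound 3 (0.31 log units; beyond the scatter), is only a floor, so the true change may be larger. The step of an at least 1.4-fold higher number from compound 2 to compound 3 (0.17 log units; that floor lies within the scatter) is also a floor, and that floor lies within the scatter. Compound 3 has no exact number, only a limit of this assay: the limit of > 1000 nM in this assay, at which 1 of the 3 values shown sits.

Going by these compounds, how a methyl or methoxy group in place of that fluoro would fare stays open, as does how far compound 3 lies past its limit.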